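The source may hold more compounds than are shown below. What is called first, only, known or untested is meant among the compounds shown, and "the series" means these compounds.

Compound 2 `CCN1CCN(c2cc(C)c3cc(NC(=O)c4ccc(Br)cc4)ccc3n2)CC1` is one of three measured members of this series. In a functional assay on SK-BR-3 cells (Homo sapiens) for antiproliferative activity, read by MTT assay, with a stated time of 72 h (on this read-out higher numbers stand for weaker inhibition and lower numbers for stronger inhibition), compound 2 gives 6310 nM. Its neighbours differ in the amine on the shared core and in the substitution of the benzamide ring: compound 1 `CNc1cc(C)c2cc(NC(=O)c3ccc(Cl)c(Cl)c3)ccc2n1` gives 6350 nM and compound 3 `Cc1cc(N2CCN(C)CC2)nc2ccc(NC(=O)c3ccc(Cl)c(Cl)c3)cc12` gives 6320 nM, so all three numbers sit within the usual scatter of one another, and compound 2 stands level with both rather than apart from them. Going by the values given here, the only measured step, a 1.0-fold lower number from compound 1 to compound 3 (0.00 log units; within the scatter), changes the amine on the core and leaves the number unmoved.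

Compound 4 `CCN1CCN(c2cc(C)c3cc(NC(=O)c4ccc(OC)cc4)ccc3n2)CC1` differs from compound 2 by methoxy in place of bromo on an aromatic carbon. Among the compounds with values here, no measured step touches the benzamide substituent, so there is no direct precedent for this change; the three measured values only show that the series has so far stayed flat. Compound 4 is therefore expected to remain close to compound 2, with an estimated step of a 1.3-fold higher number from compound 2 to compound 4 (0.10 log units; within the scatter) and a wide range. The estimate for compound 4 in this assay is 8000 nM, between 2500 nM and 25000 nM.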

Compound 4, half-maximal inhibitory concentration: 9000 nM
The estimate for compound 4 lay 1.1-fold (0.05 log units) below the measured number; the range from low to high includes it.
By their numbers in this assay, from the lowest: compounds 2, 3, 1 and 4 (each within the scatter of the next).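

Going by these compounds alone, this is the first measured change at this position, para to a large group on the benzamide ring. In this assay, methoxy in place of bromo gives a 1.4-fold higher number from compound 2 to compound 4 (0.15 log units; within the scatter), so the pair stands level, even though methoxy is counted as a hydrogen-bond acceptor and bromo is not, and the flat picture now extends from the amine on the shared core to this ring substituent for this one pair. No supporting measurement bears on why the two compounds stand level.

The compounds shown leave open whether another group at this position, such as an amine, a carboxylic acid or a longer alkoxy chain, would move the number beyond the scatter. They also leave open whether such a group would act alike with the methylamino group of compound 1 on the shared core.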